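A few compounds are considered here, and "the series" means these few. Any claim that something is new, unique, unknown or untested is made for them only; others in the source may bear on it.

Compound 1 `Nc1cc(N)c2nc(-c3ccccc3)c(Oc3ccc(Cl)c(Cl)c3)nc2c1` gives 33900 nM in a functional assay on NCI-H522 cells (Homo sapiens) for inhibition, read by sulforhodamine B assay, with a stated time of 48 h; a lower number here means a stronger inhibitor of growth, a higher number a weaker inhibitor of growth.
Compound 2 `Nc1cc(N)c2nc(-c3ccccc3)c(NCc3ccc(Cl)c(Cl)c3)nc2c1` gives 4900 nM in this assay.
Compound 3 `COc1ccc(CNc2nc3cc(N)cc(N)c3nc2-c2ccccc2)cc1OC` gives 6310 nM in this assay.

Compound 3 holds the second highest of the three numbers in this assay. Its nearest neighbour is compound 2, since the step of a 1.3-fold higher number from compound 2 to compound 3 (0.11 log units; within the scatter) lies within the scatter, a change in which a 3,4-dimethoxyphenyl replaces a 3,4-dichlorophenyl on a saturated chain carbon bound to a nitrogen on an aromatic ring. Compound 1 stands furthest away, with a clearly higher number than compound 3.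

Compound 4 `COc1cc(CNc2nc3cc(N)cc(N)c3nc2-c2ccccc2)cc(OC)c1OC` differs from compound 3 by methoxy in place of hydrogen on an aromatic carbon, a methoxy in place of hydrogen on an aromatic carbon, ortho to a methoxy group and meta to a large group. Among the measured compounds shown here, no measured pair changes the substitution of this aryl ring by a single group; the only step on that ring, a 1.3-fold higher number from compound 2 to compound 3 (0.11 log units; within the scatter), exchanged two groups at once and stayed within the scatter. A change on that ring is therefore expected to bring no step beyond the scatter. Compound 4 is expected to give 6300 nM in this assay, with a range from 2500 nM to 16000 nM. The expected step from this estimate is a 1.0-fold lower number from compound 3 to compound 4 (0.00 log units; within the scatter).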

Compound 4, concentration for total growth inhibition: < 50200 nM
Compound 4 was reported as a limit; the forecaster's own chance of this, stated with the estimate: 5%; the middle value does not contradict the limit.
By their numbers in this assay, from the lowest: compounds 2 and 3 (each within the scatter of the next); then compound 1.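

Compound 4 gives < 50200 nM in this assay, which is a limit of the assay and not a number. The step from compound 3 to compound 4 therefore cannot be read. The compounds shown leave open whether methoxy in place of hydrogen on an aromatic carbon, taken alone, changes growth inhibition at all.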